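Chlorines for fluorine on a dibenzoylhydrazine ecdysone agonist

The source may report more compounds than this note shows. Statements on the series, on what has been measured and on what is new or still open speak of the compounds shown alone.

Two measured compounds share one core. Compound 1 `CC(C)(C)N(NC(=O)c1ccccc1)C(=O)c1ccccc1I` gives 105 nM in an assay on cells for agonist activity at ecdysone receptor (Bombyx mori), read by a luciferase reporter, with a stated time of 24 h; on this read-out higher numbers stand for an effect only at larger amounts of compound and lower numbers for an effect already at smaller amounts. Compound 2 `CC(C)(C)N(NC(=O)c1cccc(F)c1)C(=O)c1ccccc1Cl` gives 69.2 nM in this assay, the lower of the two numbers, though its gap to compound 1 lies within the scatter. Compound 3 `CC(C)(C)N(NC(=O)c1cccc(Cl)c1Cl)C(=O)c1ccccc1Cl` has not been measured; it differs from compound 2 in one place: 2,3-dichlorophenyl in place of 3-fluorophenyl on a carbonyl carbon. For the measured compounds named here, with no comparable step in hand, the expected step from compound 2 to compound 3 is a 2.2-fold higher number from compound 2 to compound 3 (0.34 log units; beyond the scatter), a modest rise only slightly beyond the scatter. Compound 3 is therefore estimated at 150 nM, between 40 nM and 600 nM.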

Compound 3, half-maximal effective concentration: 9.33 nM
Compound 3: the middle estimate sits 16-fold (1.21 log units) above what was measured, and the stated range ends above it.
By their numbers in this assay, from the lowest: compound 3; then compounds 2 and 1 (each within the scatter of the next).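

For the compounds shown here, the exchange of 3-fluorophenyl for 2,3-dichlorophenyl on a carbonyl carbon gives a 7.4-fold lower number from compound 2 to compound 3 (0.87 log units; beyond the scatter) in this assay, the first comparison here of compounds that differ in one place. It shows that the number in this assay responds to the group at this position, and that this change lowers it beyond the scatter. Nothing at hand accounts for the size of this step.

As far as these compounds go, whether a single chlorine would give the same step remains open. So does how a methoxy or trifluoromethyl group at this position would compare.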